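Chain-terminal carboxylic acid appended to the hexyloxy analogue

The compounds below may be only part of what the source reports. "The series", "measured", "known", "first", "only" and "open" are said of these compounds alone.

Measured compounds:
compound 1 `CCCCCCOc1ccc2c(=O)c(-c3ccc(O)cc3)coc2c1`: 1500 nM
compound 2 `CCOC(=O)COc1ccc2c(=O)c(-c3ccc(O)cc3)coc2c1`: 130 nM
compound 3 `CC(C)Oc1ccc2c(=O)c(-c3ccc(O)cc3)coc2c1`: 80 nM

In an assay (Cricetulus griseus) for inhibition of aldehyde dehydrogenase, mitochondrial (Homo sapiens) (on this read-out higher numbers stand for weaker inhibition and lower numbers for stronger inhibition), compound 1 stands at the highest of the three numbers; the steps away from it are a 12-fold lower number from compound 1 to compound 2 (1.06 log units; beyond the scatter) and a 19-fold lower number from compound 1 to compound 3 (1.27 log units; beyond the scatter). The step of a 1.6-fold lower number from compound 2 to compound 3 (0.21 log units; within the scatter) is within the scatter, so compounds 2 and 3 cannot be ordered.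

Compound 4 `O=C(O)CCCCCCCCCCCOc1ccc2c(=O)c(-c3ccc(O)cc3)coc2c1` differs from compound 1 by 5-carboxypentyl in place of hydrogen on a saturated chain carbon, six bonds along the chain from an oxygen on an aromatic ring. Both measured steps from compound 1 shorten the alkoxy chain, one of them also bringing in an ester. Compound 4 instead lengthens the chain and ends it in a carboxylic acid, so neither step is a direct precedent. A modest change is expected, with a weak lean toward a lower number. Compound 4 is estimated at 800 nM, range 200 nM to 3000 nM. The expected step is a 1.9-fold lower number from compound 1 to compound 4 (0.27 log units; within the scatter).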

Compound 4, half-maximal inhibitory concentration: 130 nM
Beside the measured number, compound 4's estimate is 6.2-fold (0.79 log units) above it; measured number below the stated range.
By their numbers in this assay, from the lowest: compounds 3, 2 and 4 (each within the scatter of the next); then compound 1.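

In this assay the 5-carboxypentyl group gives a 12-fold lower number from compound 1 to compound 4 (1.06 log units; beyond the scatter) and so this chain position tolerates a much longer chain ending in a carboxylic acid. Until now, lower numbers had come only with shorter groups on the oxygen, while the plain hexyl chain of compound 1 stood highest. Nothing available explains the step.

Still open, from the compounds shown here alone, is whether the carboxylic acid or the added chain length carries the step; the same long chain ending in a methyl group, an ethyl ester or an amine would separate these. Also open, going by these compounds, is how a shorter chain ending in a carboxylic acid would read.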